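Substituent scan on the fused core of compound 1

A few compounds are considered here, and "the series" means these few. Any claim that something is new, unique, unknown or untested is made for them only; others in the source may bear on it.

Among the measured compounds shown here, compound 1 `CC(C)(O)c1cncc(-n2ncc3ccccc32)c1` gives 15 nM in an assay on cells for inhibition of cytochrome P450 11B2, mitochondrial (Homo sapiens), read by HTRF, with stated times of 1 h and 3 h (a higher number here means a weaker inhibitor, a lower number a stronger inhibitor), the second highest of the three numbers so far. Compound 3 `CC(C)(O)c1cncc(-n2ncc3cccc(F)c32)c1` gives 0.9 nM in this assay, and compound 2 `CC(C)(O)c1cncc(-n2nc(C3CC3)c3ccccc32)c1` gives 760 nM. The step of a 17-fold lower number from compound 1 to compound 3 (1.22 log units; beyond the scatter) is large, as is the step in the other direction, a 51-fold higher number from compound 1 to compound 2 (1.70 log units; beyond the scatter). Compound 4 `CC(C)(O)c1cncc(-n2ncc3cc(C(F)(F)F)ccc32)c1` carries the change (trifluoromethyl in place of hydrogen on an aromatic carbon). The step to compound 3 bears on it most, since it also puts a group on the six-membered carbon ring of the fused system, though a different group at a different place; the step to compound 2 concerns another ring. A change in this assay is therefore expected, with the direction uncertain, so compound 4 is estimated at 10 nM (range 2 nM to 60 nM), the expected step being a 1.5-fold lower number from compound 1 to compound 4 (0.18 log units; within the scatter).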

Compound 4, half-maximal inhibitory concentration: 507 nM
For compound 4 the middle estimate is 51-fold (1.71 log units) below the measured one, and the stated range ends below it.
By their numbers in this assay, from the lowest: compound 3; then compound 1; then compounds 4 and 2 (each within the scatter of the next).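

In this assay, trifluoromethyl on this aromatic carbon of the six-membered aromatic ring of carbon only brings a large loss: a 34-fold higher number from compound 1 to compound 4 (1.53 log units; beyond the scatter). A substituent on this ring of the core of compound 1 therefore gives no gain as such, since the step with fluoro at a different place, a 17-fold lower number from compound 1 to compound 3 (1.22 log units; beyond the scatter), runs the other way. Open, as far as these compounds go, is how fluoro, methyl, an amine or a carboxylic acid would fare on this same aromatic carbon, which would separate the place from the group. Nothing measured here gives a reason for the loss.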